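Adding an Acetamidomethyl Group to Compound 3

A few compounds are considered here, and "the series" means these few. Any claim that something is new, unique, unknown or untested is made for them only; others in the source may bear on it.

Measured compounds:
Compound 1 `Cc1cccnc1C(=O)NCc1cncc(N2C(=O)c3ccc(Cl)cc3C2(C)C)c1` gives 9 nM in an assay on cells for inhibition of cytochrome P450 11B2, mitochondrial (Homo sapiens), read by HTRF; on this read-out lower numbers stand for stronger inhibition and higher numbers for weaker inhibition.
Compound 2 `CC(=O)N1CCN(c2cncc(N3C(=O)c4ccc(Cl)cc4C3(C)C)c2)CC1` gives 9 nM in this assay.
Compound 3 `CC1(C)c2cc(Cl)ccc2C(=O)N1c1cccnc1` gives 108 nM in this assay.

Compound 3 gives the highest number of the three in this assay; compound 1 and compound 2 both lie far below it, beyond the scatter. For the measured compounds named here, the one step that bears on the change is a 12-fold higher number from compound 2 to compound 3 (1.08 log units; beyond the scatter), a large loss when the ring carbon is left bare. Compound 4 `CC(=O)NCc1cncc(N2C(=O)c3ccc(Cl)cc3C2(C)C)c1` differs from compound 3 by acetamidomethyl in place of hydrogen on an aromatic carbon, so that position is filled again, here with an amide-bearing group. Compound 4 is therefore expected to give about 20 nM, within 7 nM to 60 nM. The expected step is a 5.4-fold lower number from compound 3 to compound 4 (0.73 log units; beyond the scatter), downward and beyond the scatter.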

Compound 4, half-maximal inhibitory concentration: 59 nM
For compound 4 the middle estimate is 3.0-fold (0.47 log units) below the measured one; the measured number falls inside the stated range.
By their numbers in this assay, from the lowest: compounds 1 and 2 (each within the scatter of the next); then compounds 4 and 3 (each within the scatter of the next).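

In this assay, acetamidomethyl on this aromatic carbon brings no clear gain over hydrogen: a 1.8-fold lower number from compound 3 to compound 4 (0.26 log units; within the scatter). So filling the position is not enough, and what fills it counts: acetamidomethyl in place of 4-acetylpiperazin-1-yl gives a 6.6-fold higher number from compound 2 to compound 4 (0.82 log units; beyond the scatter), while methyl in place of 3-methylpyridin-2-yl on the carbonyl carbon gives a 6.6-fold higher number from compound 1 to compound 4 (0.82 log units; beyond the scatter). No measurement here explains these differences. Still open, as far as these compounds go, is whether the amide or the carbon link matters more, which an aminomethyl group or a longer amide chain at this position could help separate.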